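The compounds below may be only part of what the source reports. "The series", "measured", "known", "first", "only" and "open" are said of these compounds alone.

Working notes, metabolic stability series.

Measured in an in vitro ADME assay on microsomes (Mus musculus) for metabolic stability; a higher number here means that the compound lasts longer, a lower number that the compound disappears faster:
- compound 1, `CNC(=O)Nc1ccc(-c2nc(N3CC4CCC(C3)O4)c3cnn([C@H]4CC[C@@H](OC)CC4)c3n2)cc1`: compound 1 gives 0.283 h.
- compound 2, `CNC(=O)Nc1ccc(-c2nc(N3CC4CCC(C3)O4)c3cnn(C(C)C)c3n2)cc1`: compound 2 reaches the assay limit of > 0.5 h, a limit and not a number.
- compound 3, `O=C(Nc1ccc(-c2nc(N3CC4CCC(C3)O4)c3cnn(C4CCC5(CC4)OCCO5)c3n2)cc1)NC1CC1`: compound 3 gives 0.417 h.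

Compound 3 and compound 1 sit within the scatter of each other; the value of compound 2 is a limit, as noted in the limit of > 0.5 h in this assay, at which 1 of the 3 values shown sits. Among the compounds with values here, the only measured step, an at least 1.7-fold higher number from compound 1 to compound 2 (0.24 log units; that floor lies within the scatter), changes the group on the aromatic nitrogen and only gives a floor that lies within the scatter.

Compound 4, `O=C(Nc1ccncc1)Nc1ccc(-c2nc(N3CC4CCC(C3)O4)c3cnn(C4CCC5(CC4)OCCO5)c3n2)cc1`, has not been measured in this assay. It differs from compound 3 by pyridin-4-yl in place of cyclopropyl on an amide-type nitrogen. No measured step touches the amide-type nitrogen, so nothing shown bears directly on this change, and the one step that exists is itself within the scatter. The expectation is therefore a step of a 1.1-fold higher number from compound 3 to compound 4 (0.03 log units; within the scatter), not clearly beyond the scatter, with some chance that the assay reports only a limit. The estimate for compound 4 in this assay is 0.45 h, expected to fall between 0.22 h and 0.9 h.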

Compound 4, half-life: > 0.5 h
Compound 4 gave a limit, no number (the forecaster's own chance of this, stated with the estimate: 40%); middle value at least 1.1-fold (0.04 log units) away from the limit.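

In this assay compound 4 gives > 0.5 h, which is a limit and not a number. Within the data shown here, this is the first measured change on the amide-type nitrogen, and pyridin-4-yl in place of cyclopropyl gives an at least 1.1-fold higher number from compound 3 to compound 4 (0.07 log units; that floor lies within the scatter), so the swap to the larger aromatic ring shows no loss in this read-out, while the real size of the step stays unknown and only its floor is printed. Comparison within the series is now restricted by the ceiling of the read-out: the limit of > 0.5 h in this assay, at which 2 of the 4 values shown sit.

Going by these compounds, how far compound 2 and compound 4 actually lie past that limit stays open, and so does whether the pyridin-4-yl result carries over to compounds with isopropyl or 4-methoxycyclohexyl on the aromatic nitrogen. Also open, on these data alone, is whether the ring nitrogen of pyridin-4-yl matters at all, a question that a phenyl group or a longer alkyl chain on the amide-type nitrogen would address.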